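Pyrazolopyrimidine chalcone series: notes toward compound 4

The compounds below may be only part of what the source reports. "The series", "measured", "known", "first", "only" and "open" are said of these compounds alone.

Measured so far:
compound 1 `COc1ccc(-c2cc(C(=O)/C=C/c3ccccc3)nc3cc(-c4ccccc4)nn23)cc1OC`: 18600 nM
compound 2 `COc1ccc(C(=O)/C=C/c2cc(-c3cc(OC)c(OC)c(OC)c3)n3nc(-c4ccccc4)cc3n2)cc1`: 14600 nM
compound 3 `COc1ccc(-c2cc(C(=O)/C=C/c3ccc(C)cc3)nc3cc(-c4ccccc4)nn23)cc1OC`: 22200 nM

In a functional assay on A549 cells (Homo sapiens) for antiproliferative activity, read by MTT assay, with a stated time of 24 h (on this read-out higher numbers stand for weaker inhibition and lower numbers for stronger inhibition), compound 3 gives the highest of the three numbers, but its distance to compound 1 and to compound 2 is within the scatter, so no order among the three can be read. Within the data shown here, the only single-point step measured so far is a 1.2-fold higher number from compound 1 to compound 3 (0.08 log units; within the scatter).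

Compound 4 `COc1ccc(C(=O)/C=C/c2cc(-c3ccc(OC)c(OC)c3)n3nc(-c4ccccc4)cc3n2)cc1` differs from compound 3 by 2-((4-methoxyphenyl)carbonyl)ethenyl in place of (2-(4-methylphenyl)ethenyl)carbonyl on an aromatic carbon. Among the measured compounds shown here, the change is not a single-point one, and no measured step covers it directly. The nearest guide is compound 2, which carries the same entering group on a related core and in this assay gives 14600 nM; compound 3 in this assay gives 22200 nM, and these two values lie within the scatter of each other.

On that basis the expected step of a 1.3-fold lower number from compound 3 to compound 4 (0.12 log units; within the scatter) is small, with no direction beyond the scatter. Compound 4 is therefore estimated at 17000 nM in this assay, with a range from 7000 nM to 40000 nM.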

Compound 4, half-maximal inhibitory concentration: 11900 nM
Compound 4: the middle estimate sits 1.4-fold (0.15 log units) above what was measured; measured number inside the range.
By their numbers in this assay, from the lowest: compounds 4, 2, 1 and 3 (each within the scatter of the next).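

In this assay, 2-((4-methoxyphenyl)carbonyl)ethenyl in place of (2-(4-methylphenyl)ethenyl)carbonyl gives a 1.9-fold lower number from compound 3 to compound 4 (0.27 log units; within the scatter), and in place of (2-phenylethenyl)carbonyl it gives a 1.6-fold lower number from compound 1 to compound 4 (0.19 log units; within the scatter), so this read-out does not separate these groups at this position on the shared core. Hydrogen in place of methoxy on an aromatic carbon gives a 1.2-fold lower number from compound 2 to compound 4 (0.09 log units; within the scatter), so that change is not separated from the scatter either. No independent evidence bears on these results.

As far as these compounds go, it remains open whether an amine or a carboxylic acid on the aromatic ring of the 2-((4-methoxyphenyl)carbonyl)ethenyl group would move the number beyond the scatter. Also open, from the compounds shown here alone, is whether the phenyl group on the shared core contributes to the read-out at all.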